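This account rests on a few compounds, and the source may have more. Where it says the series, first, only, none or still open, it means among the compounds named here.

Measured in an ADME assay (liver) for metabolic stability, with Liver microsome (Rattus norvegicus) as the target, read by LC-MS, using microsomes and NADPH, with stated times of 5 min and 60 min, tested at 4 uM; a lower number here means that less of the compound is left, a higher number that more of the compound is left:
Compound 1 `Cc1c(OCCCCOc2ccc(C(=O)O)cc2Cl)ccc(C(=O)CC2CCCC2)c1O` gives 21%
Compound 2 `Cc1c(OCCCCOc2cccc(C(=O)O)c2)ccc(C(=O)CC(C)C)c1C` gives 29%

Compound 2, with 29%, lies within the usual scatter of compound 1, so these two numbers cannot be told apart. Compound 3 `Cc1c(OCCCCOc2ccccc2C(=O)O)ccc(C(=O)CC(C)C)c1C` has the same atoms as compound 2, joined differently: 2-carboxyphenyl in place of 3-carboxyphenyl on an oxygen on a saturated carbon, with 2-carboxyphenyl in place of 3-carboxyphenyl on an oxygen on a saturated carbon. Going by the values given here, no measured pair of compounds shows a change of this kind, so nothing beyond the scatter is expected in this assay, in either direction. The estimated change is a number 1 percentage points higher from compound 2 to compound 3 (within the scatter). For compound 3 the expected value is 30%, within an estimated range of 12% to 50%.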

Compound 3, percent of the compound remaining: 9%
For compound 3 the middle estimate is 21 percentage points above the measured one, outside the stated range (below it).
By their numbers in this assay, from the lowest: compound 3; then compounds 1 and 2 (each within the scatter of the next).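

In this assay, 2-carboxyphenyl in place of 3-carboxyphenyl on an oxygen on a saturated carbon gives a number 20 percentage points lower from compound 2 to compound 3 (beyond the scatter). Going by these compounds alone, this is the first step between compounds that differ in one place, and it shows that rejoining the same atoms at this position is enough to shift the number beyond the scatter. Nothing available explains this shift. The compounds shown leave open whether an amide or a tetrazole in place of the carboxylic acid would give a similar number. They also leave open whether the step would carry over to the core of compound 1.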